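From heptyl to hept-1-yn-1-yl on the shared core

The source may hold more compounds than are shown below. What is called first, only, known or untested is meant among the compounds shown, and "the series" means these compounds.

Compound 1 `CCCCCCCCCCCc1cc2cn(COCCO)c(=O)nc2o1`, compound 2 `CCCCCCCc1cc2cn(COCCO)c(=O)nc2o1` and compound 3 `CCCCCCCCCCc1cc2cn(COCCO)c(=O)nc2o1` share one core and differ only in the length of a saturated chain. In a functional assay on HEL cells (Homo sapiens) (on this read-out higher numbers stand for lower toxicity in this test and lower numbers for higher toxicity in this test), compound 1 gives 132000 nM and compound 2 gives 140000 nM. These two values lie within the scatter of each other, as a 1.1-fold higher number from compound 1 to compound 2 (0.03 log units; within the scatter) shows. Compound 3 reports only a limit, > 200000 nM. The steps to that limit give floors only, an at least 1.5-fold higher number from compound 1 to compound 3 (0.18 log units; that floor lies within the scatter) and an at least 1.4-fold higher number from compound 2 to compound 3 (0.15 log units; that floor lies within the scatter), and both floors lie within the scatter.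

Compound 4 `CCCCCC#Cc1cc2cn(COCCO)c(=O)nc2o1` keeps the core of compound 2 and changes the chain: hept-1-yn-1-yl in place of heptyl on an aromatic carbon. In words, hept-1-yn-1-yl stands in place of heptyl on an aromatic carbon. No measured step covers a triple bond, so the chain-length steps are the only guide, and none of them is shown to go beyond the scatter. No step beyond the scatter is therefore expected, and the estimated step is no change at the digits printed from compound 2 to compound 4 (within the scatter). For compound 4 the estimate is 140000 nM, with an expected range from 60000 nM to 280000 nM.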

Compound 4, half-maximal cytotoxic concentration: > 50000 nM
Compound 4 ended at the assay's limit; the forecaster's own chance of this, stated with the estimate: 35%; the middle value lies beyond the limit too.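

For compound 4 the limit > 50000 nM is all that this assay reports, so the step from compound 2 to compound 4 cannot be read. The compounds shown leave open whether hept-1-yn-1-yl in place of heptyl changes the number at all, and in which direction.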